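Benzyl Groups on a Sulfur: From Thiol to Difluorobenzyl

A few compounds are considered here, and "the series" means these few. Any claim that something is new, unique, unknown or untested is made for them only; others in the source may bear on it.

Measured so far in a functional assay on MCF7 cells (Homo sapiens) for cytotoxicity, read by MTT assay, with a stated time of 24 h; on this read-out higher numbers stand for weaker inhibition and lower numbers for stronger inhibition:
Compound 1 `Cn1nc(-c2nnc(S)o2)cc1-c1ccc(C(F)(F)F)cc1` gives > 100000 nM, which is a limit of the assay and not a number.
Compound 2 `Cn1nc(-c2nnc(SCc3cccc(Cl)c3Cl)o2)cc1-c1ccc(C(F)(F)F)cc1` gives 32200 nM.
Compound 3 `Cn1nc(-c2ccc(C(F)(F)F)cc2)cc1-c1nnc(S)o1` gives > 100000 nM, again a limit of the assay and not a number.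

Compound 3 therefore stands at the top of the measured range, with no number of its own; two of the three values sit at the limit of > 100000 nM in this assay, at which 2 of the 3 values shown sit. Compound 4 `Cn1nc(-c2ccc(C(F)(F)F)cc2)cc1-c1nnc(SCc2c(F)cccc2F)o1` differs from compound 3 in one place: 2,6-difluorobenzyl in place of hydrogen on a sulfur. Within the data shown here, the only measured step of this kind is an at least 3.1-fold lower number from compound 1 to compound 2 (0.49 log units; beyond the scatter), where a benzyl group entered on a sulfur in place of hydrogen. A step of the same direction is expected for compound 4 in this assay, estimated as an at least 2.5-fold lower number from compound 3 to compound 4 (0.39 log units; beyond the scatter). Compound 4 is accordingly estimated at 40000 nM, with an expected range from 15000 nM to 150000 nM.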

Compound 4, half-maximal inhibitory concentration: 46200 nM
Beside the measured number, compound 4's estimate is 1.2-fold (0.06 log units) below it; the range from low to high includes it.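

In this assay, 2,6-difluorobenzyl on the sulfur gives an at least 2.1-fold lower number from compound 3 to compound 4 (0.33 log units; beyond the scatter). Together with the earlier step, this shows that a substituted benzyl group on the sulfur lowers the number on two different thiols, with chlorine on the ring in one case and fluorine in the other. Compound 3 starts from a limit of the assay, not a number, so this step has only a lower bound: the limit of > 100000 nM in this assay, at which 2 of the 4 values shown sit.

Still open, from the compounds shown here alone, is how a plain benzyl group, a methyl group or a longer alkyl chain on the same sulfur would compare. A benzyl ring carrying an amine or a carboxylic acid is also untested here.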